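This account rests on a few compounds, and the source may have more. Where it says the series, first, only, none or still open, it means among the compounds named here.

Series notes. Three compounds of one core have been run in a functional assay on SK-MEL-28 cells (Homo sapiens) for cytotoxicity, read by sulforhodamine B assay, with a stated time of 48 h, tested at 0.001 uM; a higher number here means a weaker effect of the compound at the concentration tested, a lower number a stronger effect. Compound 1, `COc1cc(C)cc(-c2c(-c3ccnc(-c4ccc(C(C)=O)cc4)c3)cnn2CC#N)c1`, gives 90% in this assay. Compound 2, `Cc1cc(O)cc(-c2nn(CC#N)cc2-c2ccnc(-c3ccc(Oc4ccccc4)cc3)c2)c1`, gives 91%. Compound 3, `COc1cc(C)cc(-c2nn(CC#N)cc2-c2ccnc(-c3ccc(N(C)C)cc3)c2)c1`, gives 100%. Compound 3 thus sits at the top of the three numbers, but the gap to compound 2 and the gap to compound 1 both lie within the scatter of this assay, so the three compounds are not separated by their data; at the concentration tested none of them shows more than a marginal effect.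

The next compound, compound 4, `Cc1cc(O)cc(-c2nn(CC#N)cc2-c2ccnc(-c3ccc(N(C)C)cc3)c2)c1`, is compound 3 with one change: hydrogen in place of methyl on an oxygen on an aromatic ring. The same hydroxy on the methylphenyl is already present in compound 2, whose number sits within the scatter of compound 3. Going by the values given here, no step between measured compounds is available for this change, so the expectation rests only on that comparison.

The step from compound 3 to compound 4 is expected to be small and, if anything, slightly downward, a number 6 percentage points lower from compound 3 to compound 4 (within the scatter), which is not beyond the scatter. For compound 4 in this assay the estimate is 94%, with a range from 84% to 104%.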

Compound 4, a percentage reported as activity, at one concentration (the size of the read-out at that concentration, not a potency): 102%
For compound 4 the middle estimate is 8 percentage points below the measured one, within the range that was stated.
By their numbers in this assay, from the lowest: compounds 1, 2, 3 and 4 (each within the scatter of the next, the first and the last beyond it).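

In this assay, the exchange of methoxy for hydroxy on this oxygen can now be read directly, with the dimethylamino group held fixed: a number 2 percentage points higher from compound 3 to compound 4 (within the scatter). In this pair, the 3-methoxy-5-methylphenyl and the 3-hydroxy-5-methylphenyl are therefore not separated at the concentration tested, which the earlier comparison across compounds that differed in more than one place could not show. With the hydroxy held fixed, dimethylamino in place of phenoxy on an aromatic carbon gives a number 11 percentage points higher from compound 2 to compound 4 (beyond the scatter), a modest step and the only one so far that leaves the scatter, while no measurement at hand accounts for either step.

On these data alone, whether the phenoxy to dimethylamino step also appears with methoxy on the aromatic ring remains open, as does the effect of a longer chain such as ethoxy on this oxygen or of a carboxylic acid in place of the dimethylamino group. All of these numbers come from a single concentration, so they describe only how strong or weak the effect of each compound is at that concentration.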